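Alkoxy chain variation in an isoquinolinone acid series

A few compounds are considered here, and "the series" means these few. Any claim that something is new, unique, unknown or untested is made for them only; others in the source may bear on it.

Three compounds of the series carry a measurement in an ADME assay on the whole organism (Mus musculus, strain CD1) for metabolic stability, read by LC-MS, with a stated time of 24 h, at a dose of 1 mg/kg by the intravenous route; on this read-out lower numbers stand for a shorter-lived compound and higher numbers for a longer-lived compound. Compound 1 `O=C(O)Cn1nc(Cc2nc3cc(Cl)c(OCC(F)F)cc3[nH]2)c2ccccc2c1=O` gives 0.3 h in this assay, the lowest of the three numbers shown. Compound 3 `C[C@H](C(=O)O)c1nn(Cc2cn3cc(OCC4CC4)c(Cl)cc3n2)c2ccccc2c1=O` gives 0.8 h and stands nearest to compound 1, yet beyond the scatter; compound 2 `C[C@H](C(=O)O)n1nc(Cn2cc3cc(OCC4CC4)c(Cl)cc3n2)c2ccccc2c1=O` gives 2.4 h and stands furthest from it. Within the data shown here, none of these pairs differ in a single place, so no step between measured compounds can be read.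

Compound 4 `CCOc1cc2[nH]c(Cc3nn(CC(=O)O)c(=O)c4ccccc34)nc2cc1Cl` is the next compound to go into this assay. It differs from compound 1 in one place: methyl in place of difluoromethyl on a saturated chain carbon bound to an oxygen on an aromatic ring. Among the measured compounds shown here, no measured pair shows the effect of this change, so nothing in the data points in either direction. The expected step from compound 1 to compound 4 in this assay is no change at the digits printed from compound 1 to compound 4 (within the scatter), taken as none beyond the scatter. Compound 4 is therefore estimated at 0.3 h, within a range of 0.12 h to 0.7 h.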

Compound 4, half-life: 0.3 h
Beside the measured number, compound 4's estimate shows no gap at the digits printed; low and high end bracket the measured number.
By their numbers in this assay, from the lowest: compounds 1 and 4 (each within the scatter of the next); then compound 3; then compound 2.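

In this assay, among these compounds, methyl in place of difluoromethyl on a saturated chain carbon bound to an oxygen on an aromatic ring gives no change at the digits printed from compound 1 to compound 4 (within the scatter), the only step that can be read at this position. On the core of compound 1, the read-out therefore does not separate 2,2-difluoroethoxy from ethoxy, so removing the two fluorine atoms leaves no visible mark on half-life. Nothing at hand offers an explanation for this result.

Still open, from the compounds shown here alone, is whether a longer chain, a trifluoromethyl group in place of the methyl, or an amine on this chain would shift the half-life on this core. Also open, going by these compounds, is whether the same change would read alike on the cores of compound 2 and compound 3, which differ from compound 1 in more than one place.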